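Methyl for methoxy: transfer of one step across cores

A few compounds are considered here, and "the series" means these few. Any claim that something is new, unique, unknown or untested is made for them only; others in the source may bear on it.

Compound 1 `COc1ccc2[nH]c3c(c4c(c5ccnn53)C(=O)NC4=O)c2c1` gives 34000 nM in a functional assay on LoVo cells (Homo sapiens) for cytotoxicity, read by MTT assay, with a stated time of 72 h; a higher number here means a weaker inhibitor, a lower number a stronger inhibitor. Compound 2 `Cc1ccc2[nH]c3c(c4c(c5ccnn53)C(=O)NC4=O)c2c1` carries the change methyl in place of methoxy on an aromatic carbon and gives 4000 nM in this assay; the step is an 8.5-fold lower number from compound 1 to compound 2 (0.93 log units; beyond the scatter). Compound 3 `COc1ccc2[nH]c(-n3cccn3)cc2c1` rests on a different core; the difference between the two cores is not broken down here. In this assay compound 3 gives 70000 nM, the highest of the three measured numbers. Compound 4 `Cc1ccc2[nH]c(-n3cccn3)cc2c1` carries the same kind of change, (methyl in place of methoxy on an aromatic carbon), though here the ring is part of a fused or bridged system of two rings rather than five. Within the data shown here, the expected step is a 3.9-fold lower number from compound 3 to compound 4 (0.59 log units; beyond the scatter), set somewhat smaller than an 8.5-fold lower number from compound 1 to compound 2 (0.93 log units; beyond the scatter) since only that single precedent, on another core, supports it. Compound 4 is therefore estimated at 18000 nM, between 6000 nM and 55000 nM.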

Compound 4, half-maximal inhibitory concentration: 87000 nM
Beside the measured number, compound 4's estimate is 4.8-fold (0.68 log units) below it, and the stated range ends below it.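

In this assay, methyl in place of methoxy on an aromatic carbon gives a 1.2-fold higher number from compound 3 to compound 4 (0.09 log units; within the scatter), so the step seen on the core of compound 1 does not carry over to the core of compound 3, and the two steps differ: the same change on two cores in this assay, an 8.5-fold lower number (0.93 log units; beyond the scatter) from compound 1 to compound 2 and a 1.2-fold higher number (0.09 log units; within the scatter) from compound 3 to compound 4, 11-fold (1.02 log units) apart, beyond the scatter of two such steps.
The change therefore cannot be treated as transferable between these two cores. With a single pair on each core, this does not show what underlies the difference or how the change would behave on any other core.

Still open, as far as these compounds go, is whether another group at this place, such as chloro or an amine, would lower the number on both cores or on only one. Also open, from the compounds shown here alone, is whether the core of compound 3 responds to any substitution here.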